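Hydrogen for methoxy on compound 1

A few compounds are considered here, and "the series" means these few. Any claim that something is new, unique, unknown or untested is made for them only; others in the source may bear on it.

Compound 1 (`COc1ccc(-c2nc3sc(-c4ccccc4)cn3n2)cc1`) gives 37% in a functional assay on OVCAR-4 cells (Homo sapiens) for inhibition, read by sulforhodamine B assay, with a stated time of 48 h, tested at 10 uM (a lower number here means less inhibition of growth, a higher number more inhibition of growth at the concentration tested), and stands second highest of the three numbers in hand. Compound 2 (`COc1cc(-c2nc3sc(-c4ccccc4)cn3n2)cc(OC)c1OC`) gives 17% on the low side and compound 3 (`Clc1ccc(-c2cn3nc(-c4ccccc4)nc3s2)cc1`) gives 60% on the high side, each gap lying beyond the scatter. No two of these compounds differ in one place only, so no measured step isolates a single group.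

Compound 4 (`c1ccc(-c2nc3sc(-c4ccccc4)cn3n2)cc1`) differs from compound 1 by hydrogen in place of methoxy on an aromatic carbon in a single place: hydrogen in place of methoxy on an aromatic carbon, para to a large group. Compound 1 at 37% and compound 2 at 17% both carry methoxy, yet their numbers stand apart, so methoxy alone does not fix the read-out. On these data alone, the data hold no direct measure of this change, and the direction of any shift remains open. For the measured compounds named here, the estimated a number 4 percentage points lower from compound 1 to compound 4 (within the scatter) is expected to stay within the scatter, with no real step in this assay as the working expectation. Compound 4 is expected at 33% in this assay with an estimated range from 15% to 55% for the coming measurement.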

Compound 4, percent growth inhibition at one concentration: 23%
Compound 4: the middle estimate sits 10 percentage points above what was measured; measured number inside the range.
By their numbers in this assay, from the lowest: compounds 2 and 4 (each within the scatter of the next); then compound 1; then compound 3.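

For the compounds shown here, the first single-place steps show that the substituent matters in this assay: going from methoxy to hydrogen para to a large group gives a number 14 percentage points lower from compound 1 to compound 4 (beyond the scatter), and going from chloro to hydrogen gives a number 37 percentage points lower from compound 3 to compound 4 (beyond the scatter), the large step of the two. Going by these compounds alone, in both steps, the compound with hydrogen in place of the group gives the lower number, so the unsubstituted compound 4 serves as a common reference, although this reading rests on these two steps alone and compound 2, joined to compound 4 by no single-place step, adds nothing to it. No supporting data bear on why either group raises the number, so the result stands as an observation only.

Compounds 1 and 3 differ in more than one place, so the two steps do not rank methoxy against chloro at a single position. Also open, on these data alone, is how an amine, a carboxylic acid, a fluoro group or a longer chain such as ethoxy would compare with methoxy and hydrogen at this para position, and whether chloro there would match the larger step.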